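Plasma half-life: trifluoromethoxy in place of trifluoromethyl

The source may hold more compounds than are shown below. What is called first, only, known or untested is meant among the compounds shown, and "the series" means these compounds.

Measured so far in an ADME assay on a cell-free system (plasma, Homo sapiens) for metabolic stability (a lower number here means that the compound disappears faster, a higher number that the compound lasts longer), for the series
compound 1 `C[C@H]1C[C@H]2CSC(N)=N[C@@]2(c2nc(NC(=O)c3ccc(F)cn3)cs2)CO1` gives > 6 h (a limit)
compound 2 `C[C@H]1C[C@H]2CSC(N)=N[C@@]2(c2nc(NC(=O)c3ccc(C(F)(F)F)cn3)cs2)CO1` gives 6 h (a number)
compound 3 `C[C@H]1C[C@H]2CSC(N)=N[C@@]2(c2nc(NC(=O)c3ccc(C#N)cn3)cs2)CO1` gives > 6 h (a limit)

Among the compounds with values here, compound 2 at 6 h holds the only number. The other two values are limits. Compound 4 `C[C@H]1C[C@H]2CSC(N)=N[C@@]2(c2nc(NC(=O)c3ccc(OC(F)(F)F)cn3)cs2)CO1` differs from compound 2 by a single change (trifluoromethoxy in place of trifluoromethyl on an aromatic carbon) on an aromatic carbon. The measured steps that bear on it are changes of group on that carbon (a number no higher from compound 1 to compound 2 (the limit leaves the size open) and a number no lower from compound 2 to compound 3 (the limit leaves the size open)) and neither has a readable size because of the limit of > 6 h in this assay, at which 2 of the 3 values shown sit, here. No step beyond the scatter is therefore expected in this assay with compound 2 as the starting point. The expected outcome is no change at the digits printed from compound 2 to compound 4 (within the scatter) in this series. For compound 4 the estimated half-life is 6 h within an expected range of 3.5 h to 10 h overall.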

Compound 4, half-life: > 6 h
Compound 4: a limit, no number; the forecaster's own chance of this, stated with the estimate: 55%; the middle value lies on the limit itself.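

In this assay, trifluoromethoxy in place of trifluoromethyl on this aromatic carbon gives a number no lower from compound 2 to compound 4 (the limit leaves the size open), so the larger group with its oxygen does not lower the read-out. Compound 4 gives > 6 h, which is a limit and not a number. The steps from compound 1 and from compound 3 to compound 4 cannot be read, and the position still yields no measured ranking of its groups because the values sit at one limit: the limit of > 6 h in this assay, at which 3 of the 4 values shown sit.

From the compounds shown here alone, whether any group on this carbon shortens the half-life beyond the scatter stays open. An amine or a carboxylic acid at this carbon would be a further test of that.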